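Methylcarbamoyl-piperidine for carbamoylmethyl-piperazine: expected solubility

A few compounds are considered here, and "the series" means these few. Any claim that something is new, unique, unknown or untested is made for them only; others in the source may bear on it.

Measured so far in a physicochemical assay for solubility, with a stated time of 20 h, at pH 6.8; a lower number here means a less soluble compound, a higher number a more soluble compound:
Compound 1, `O=S1(=O)Cc2nc(-c3cc(F)c(Cl)cc3F)nc(N3CCC(O)CC3)c2C1`, gives 91000 nM.
Compound 2, `NC(=O)CCC1CCN(c2nc(-c3cc(F)c(Cl)cc3F)nc3c2CS(=O)(=O)C3)CC1`, gives 8000 nM.
Compound 3, `NC(=O)CN1CCN(c2nc(-c3cc(F)c(Cl)cc3F)nc3c2CS(=O)(=O)C3)CC1`, gives > 100000 nM, which is a limit of the assay and not a number.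

Compound 3 therefore sits at the limit of > 100000 nM in this assay, at which 1 of the 3 values shown sits, and its exact solubility is not known. Compound 4, `CNC(=O)C1CCN(c2nc(-c3cc(F)c(Cl)cc3F)nc3c2CS(=O)(=O)C3)CC1`, differs from it in one place: 4-(methylcarbamoyl)piperidin-1-yl in place of 4-(carbamoylmethyl)piperazin-1-yl on an aromatic carbon. Going by the values given here, no measured step covers this change directly. The step of an at least 1.0-fold higher number from compound 1 to compound 3 (0.04 log units; that floor lies within the scatter) carried compound 3 up to the limit, while the step of an 11-fold lower number from compound 1 to compound 2 (1.06 log units; beyond the scatter) brought the number down sharply when an amide-bearing chain replaced hydroxy. Compound 4 carries its amide within 4-(methylcarbamoyl)piperidin-1-yl, which makes it resemble compound 2 more than compound 3. On that basis a downward step is expected from compound 3 to compound 4, an at least 3.3-fold lower number from compound 3 to compound 4 (0.52 log units; beyond the scatter), landing between the values of compound 2 and the limit. The estimate for compound 4 is 30000 nM, with a range from 8000 nM to 100000 nM.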

Compound 4, solubility: 11000 nM
The estimate for compound 4 lay 2.7-fold (0.44 log units) above the measured number, and the stated range covers the measured number.
By their numbers in this assay, from the lowest: compounds 2 and 4 (each within the scatter of the next); then compound 1. At a limit, above all of these: compound 3.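

In this assay, 4-(methylcarbamoyl)piperidin-1-yl in place of 4-(carbamoylmethyl)piperazin-1-yl on this aromatic carbon gives an at least 9.0-fold lower number from compound 3 to compound 4 (0.95 log units; beyond the scatter), so two groups of equal heavy-atom count, each carrying an amide, are clearly apart here. Compound 3 stands at a limit of the assay, not at a number: the limit of > 100000 nM in this assay, at which 1 of the 4 values shown sits. Methylcarbamoyl and 2-carbamoylethyl on the saturated ring carbon cannot be told apart, with a 1.4-fold higher number from compound 2 to compound 4 (0.14 log units; within the scatter), while methylcarbamoyl in place of hydroxy gives an 8.3-fold lower number from compound 1 to compound 4 (0.92 log units; beyond the scatter).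

This change swaps the ring and moves the amide together, so the compounds shown leave open which of the two accounts for the drop. A 4-(carbamoylmethyl)piperidin-1-yl group would separate them, and a carboxylic acid or an amine on the piperidine remains an open comparison with hydroxy and the amides.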